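The compounds below may be only part of what the source reports. "The series", "measured", "known", "first", "only" and "open" are said of these compounds alone.

Compounds measured so far in an assay on CHO-K1 cells for displacement of a labelled ligand from melanin-concentrating hormone receptor 1 (Homo sapiens), read by scintillation proximity assay, with a stated time of 2 h; on this read-out higher numbers stand for weaker inhibition and lower numbers for stronger inhibition:
compound 1 `Cc1nc(NCCNC(=O)C2CC2)nc2ccc(NC(=O)/C=C/c3ccc(OC(F)(F)F)cc3)cc12`, 61 nM
compound 2 `Cc1nc(N2CCC(N3CCCC3=O)CC2)nc2ccc(NC(=O)/C=C/c3ccc(Cl)cc3)cc12`, 74 nM

Compound 2 holds the higher of the two numbers, but its gap to compound 1 lies within the scatter, so no order between them is claimed. Compound 3 `Cc1nc(N2CCC(N3CCCC3=O)CC2)nc2ccc(NC(=O)/C=C/c3ccc(OC(F)(F)F)cc3)cc12` differs from compound 2 by trifluoromethoxy in place of chloro on an aromatic carbon. Going by the values given here, no measured pair isolates this change, so the expectation rests on the two values alone: compound 1, which also bears trifluoromethoxy at that position, gives 61 nM, close to compound 2. The step from compound 2 to compound 3 is therefore expected to be small, a 1.2-fold lower number from compound 2 to compound 3 (0.09 log units; within the scatter), not beyond the scatter. Compound 3 is estimated at 60 nM, within 25 nM to 150 nM.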

Compound 3, half-maximal inhibitory concentration: 11 nM
The estimate for compound 3 lay 5.5-fold (0.74 log units) above the measured number; measured number outside the range, below it.
By their numbers in this assay, from the lowest: compound 3; then compounds 1 and 2 (each within the scatter of the next).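

In this assay, with 4-(2-oxopyrrolidin-1-yl)piperidin-1-yl held fixed, 4-(trifluoromethoxy)phenyl in place of 4-chlorophenyl gives a 6.7-fold lower number from compound 2 to compound 3 (0.83 log units; beyond the scatter), so the group on this aromatic carbon does affect the read-out. With trifluoromethoxy held fixed, 4-(2-oxopyrrolidin-1-yl)piperidin-1-yl in place of (2-((cyclopropylcarbonyl)amino)ethyl)amino gives a 5.5-fold lower number from compound 1 to compound 3 (0.74 log units; beyond the scatter), so the second position matters as well. The close values of compound 1 and compound 2, which differ in both places, had concealed both steps.

No measurement shown here bears on the reason for either step. Still open, on these data alone, is how methoxy, trifluoromethyl or plain hydrogen would read on this aromatic carbon.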